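The source may report more compounds than this note shows. Statements on the series, on what has been measured and on what is new or still open speak of the compounds shown alone.

Series notes. Compound 1 `N#Cc1c(NCc2ccc(F)cc2)sc2c1CCN(C(=O)c1ccn[nH]1)C2` shares the core of the set; for compound 1 the entry in a functional assay on cells (kidney) for antagonist activity at metabotropic glutamate receptor 5 (Homo sapiens), read by fluorescence and calcium flux (on this read-out higher numbers stand for weaker inhibition and lower numbers for stronger inhibition), reads "not determined" (no result reported), so no result was reported. For the measured compounds named here, compound 2 `COc1ccc(C(=O)N2CCc3c(sc(NCc4ccc(F)cc4)c3C#N)C2)cc1` is the only member with a number in this assay, where compound 2 gives 1430 nM; with compound 1 lacking a value, compound 2 stands alone and no comparison within the measured set can be drawn. Compound 3 `COc1ccc(C(=O)N2CCc3c(sc(NCc4cccc(F)c4)c3C#N)C2)cc1` is not yet measured. The change from compound 2 to compound 3 is 3-fluorophenyl in place of 4-fluorophenyl on a saturated chain carbon bound to a nitrogen on an aromatic ring. Going by the values given here, no step between measured compounds is available to calibrate this exchange, and nothing in the data points to one direction over the other. The expected step of a 1.0-fold higher number from compound 2 to compound 3 (0.02 log units; within the scatter) is therefore taken as small, in either direction, and not beyond the usual scatter of this assay. For compound 3 the estimate in this assay is 1500 nM, with a range from 500 nM to 4500 nM.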

Compound 3, half-maximal inhibitory concentration: 4730 nM
Compound 3: the middle estimate sits 3.2-fold (0.50 log units) below what was measured; the whole stated range lies below it.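

In this assay, for the compounds shown here, a 3.3-fold higher number from compound 2 to compound 3 (0.52 log units; beyond the scatter), which gives the first reading at this place and shows that the exchange of 4-fluorophenyl for 3-fluorophenyl is not neutral. The two compounds carry the same atoms, and the groups have the same heavy-atom and hydrogen-bond counts, so a rearrangement alone, on the saturated chain carbon bound to a nitrogen on an aromatic ring, is enough to move the number beyond the scatter, with 4-fluorophenyl the better of this pair. Nothing available bears on why the two groups differ.

As far as these compounds go, whether unsubstituted phenyl or 4-chlorophenyl at this place would match compound 2 or fall nearer compound 3 remains open. Going by these compounds alone, no step involving compound 1 can be read, so it is also unknown whether the preference holds with a different acyl group on the shared core.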